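Fluorobenzyl in place of sec-butyl on the aromatic nitrogen

The source may hold more compounds than are shown below. What is called first, only, known or untested is meant among the compounds shown, and "the series" means these compounds.

Compound 1, `CC(C)CCn1nc(-c2ccn(C)c2)c(O)c(C2=NS(=O)(=O)c3cc(NS(C)(=O)=O)ccc3N2)c1=O`, gives 0.633 h in an in vitro ADME assay on microsomes from liver (Homo sapiens) for metabolic stability, tested at 5 uM; a higher number here means that the compound lasts longer, a lower number that the compound disappears faster.
Compound 2, `CC(C)CCn1nc(-c2ccccc2)c(O)c(C2=NS(=O)(=O)c3cc(NS(C)(=O)=O)ccc3N2)c1=O`, gives 0.633 h in this assay.
Compound 3, `CCC(C)n1nc(-c2cccs2)c(O)c(C2=NS(=O)(=O)c3cc(NS(C)(=O)=O)ccc3N2)c1=O`, reaches only > 1 h in this assay.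

Compound 3 stands at a limit of this assay rather than at a number, and the limit of > 1 h in this assay, at which 1 of the 3 values shown sits, records that it is the only one of the three to do so. The step to compound 4, `CS(=O)(=O)Nc1ccc2c(c1)S(=O)(=O)N=C(c1c(O)c(-c3cccs3)nn(Cc3ccc(F)cc3)c1=O)N2`, which is not yet measured, is 4-fluorobenzyl in place of sec-butyl on an aromatic nitrogen. Going by the values given here, the one measured step, no change at the digits printed from compound 1 to compound 2 (within the scatter), changes a substituent on an aromatic carbon and is within the scatter; it does not touch the aromatic nitrogen, so no measured step bears directly on the change from compound 3 to compound 4. With no evidence of movement among the measured compounds, the expected step in this assay is none beyond the scatter. Compound 4 is therefore estimated at 1.2 h, with a range from 0.6 h to 2.5 h. This corresponds to an expected step that the limit leaves unreadable from compound 3 to compound 4, and the assay may well return only a limit again for compound 4.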

Compound 4, half-life: > 1 h
Compound 4 ended at the assay's limit (the forecaster's own chance of this, stated with the estimate: 55%); the middle value is on the limit's open side.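

In this assay, going by these compounds alone, compound 3 and compound 4 each give a limit, not a number, and no step between them can be read. The compounds shown leave open the actual half-life of each, and whether 4-fluorobenzyl in place of sec-butyl on the aromatic nitrogen changes it at all.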